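This account rests on a few compounds, and the source may have more. Where it says the series, first, only, none or still open, it means among the compounds named here.

The measured compounds:
Compound 1 `CCOC(=O)C1=Cc2ccccc2OC1(OCc1cc(-c2ccc(C)cc2)no1)C(F)(F)F` gives > 150000 nM in a functional assay on DU-145 cells (Homo sapiens) for inhibition, read by MTT assay, with a stated time of 24 h (a lower number here means a stronger inhibitor, a higher number a weaker inhibitor), a value that is a limit of the assay and not a number.
Compound 2 `CCOC(=O)C1=Cc2ccccc2OC1(OCc1cn(CC(=O)Nc2ccc(C)cc2)nn1)C(F)(F)F` gives > 150000 nM in this assay, likewise a limit.
Compound 3 `Cc1ccc(-c2cc(COC3(C(F)(F)F)Oc4ccccc4C=C3C(=O)O)on2)cc1` gives 41400 nM in this assay.

Within the data shown here, compound 3 thus stands as the only measured number in this assay; the other two values sit at a limit, as summarized by the limit of > 150000 nM in this assay, at which 2 of the 3 values shown sit. Among the measured compounds shown here, the one measured step, an at least 3.6-fold lower number from compound 1 to compound 3 (0.55 log units; beyond the scatter), concerns the change from ethyl ester to free acid and has nothing in common with the change now in question. Compound 4 `O=C(O)C1=Cc2ccccc2OC1(OCc1cc(-c2ccc([N+](=O)[O-])cc2)no1)C(F)(F)F` differs from compound 3 by nitro in place of methyl on an aromatic carbon. For the measured compounds named here, no measured step touches a substituent on that aromatic ring, and compound 2, whose value is a limit, carries a different linker and offers no guidance either. Without a comparable step, the expectation for this assay is a change no larger than the scatter, with wide uncertainty and a real chance that the assay again returns only a limit. Compound 4 is therefore expected to give 40000 nM, within a range from 12000 nM to 150000 nM. The step of a 1.0-fold lower number from compound 3 to compound 4 (0.01 log units; within the scatter) is estimated to be small.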

Compound 4, half-maximal inhibitory concentration: 100000 nM
For compound 4 the middle estimate is 2.5-fold (0.40 log units) below the measured one; the measured number falls inside the stated range.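

Among these compounds, until now, the only step that could be read concerned the ester and the free acid, so nothing showed whether the aromatic end of the molecule mattered. With 4-methylphenyl changed to 4-nitrophenyl in this assay, the step is a 2.4-fold higher number from compound 3 to compound 4 (0.38 log units; beyond the scatter), so a substituent on this aromatic carbon, para to a large group, does affect the number: with the carboxylic acid kept, nitro gives a modestly weaker inhibitor than methyl. Compound 4 still returns a measured number, while compound 1 and compound 2 each stay at a limit of the assay: the limit of > 150000 nM in this assay, at which 2 of the 4 values shown sit.

This single pair gives one comparison at this position, so it cannot say whether an amine, a methoxy group or a chlorine atom there would fall nearer compound 3, nearer compound 4 or outside both. It also leaves open whether the same change would matter on the ethyl ester, where compound 1 gives only a limit, or with the triazole-bearing amide chain of compound 2, which also gives only a limit.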